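This account rests on a few compounds, and the source may have more. Where it says the series, first, only, none or still open, it means among the compounds named here.

Measured so far:
compound 1 `N#Cc1cc(-c2ccc3scnc3c2)ccc1-c1cccnc1` — > 10000 nM
compound 2 `Cc1nc2cc(-c3ccc(-c4ccc(F)cc4)c(C#N)c3)ccc2s1` — 4680 nM

In an in vitro assay on HEK-293T cells for displacement of a labelled ligand from metabotropic glutamate receptor 5 (Rattus norvegicus), read by scintillation counting (on this read-out lower numbers stand for stronger inhibition and higher numbers for weaker inhibition), compound 1 reaches only a limit of the assay, > 10000 nM. Compound 2 gives 4680 nM in this assay, the single number shown in the series. Compound 3 `Cc1nc2cc(-c3ccc(OCc4ccccc4)c(C#N)c3)ccc2s1` carries benzyloxy in place of 4-fluorophenyl on an aromatic carbon. Within the data shown here, no step between measured compounds is known, and the limit of > 10000 nM in this assay, at which 1 of the 2 values shown sits, gives no size for any change. The step from compound 2 to compound 3 is expected to be small, toward weaker binding at most, a 1.5-fold higher number from compound 2 to compound 3 (0.17 log units; within the scatter). Compound 3 is estimated at 7000 nM, between 1500 nM and 30000 nM.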

Compound 3, inhibition constant: 7130 nM
Beside the measured number, compound 3's estimate is 1.0-fold (0.01 log units) below it, and the stated range covers the measured number.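

In this assay, benzyloxy in place of 4-fluorophenyl on this aromatic carbon, ortho to a cyano group, gives a 1.5-fold higher number from compound 2 to compound 3 (0.18 log units; within the scatter). This first readable step shows that the position can hold either group, including the hydrogen-bond acceptor of benzyloxy, without separating compound 2 and compound 3 on this read-out. Nothing shown accounts for the size of this step.

The value of compound 1, > 10000 nM, is a limit of the assay, and steps to it cannot be read. Going by these compounds, whether an amine, a carboxylic acid or a longer chain at this position would give a step beyond the scatter remains open.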